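The source may hold more compounds than are shown below. What is called first, only, known or untested is meant among the compounds shown, and "the series" means these compounds.

Among the compounds with values here, compound 1 `COc1ccc(N(C)c2ccnc(Cl)n2)cc1` gives 917 nM in a functional assay on HeLa cells (Homo sapiens) for antiproliferative activity, read by MTT assay, with a stated time of 48 h (on this read-out lower numbers stand for stronger inhibition and higher numbers for weaker inhibition), and stands lowest of the three numbers measured so far. Compound 2 `COc1ccc(N(C)c2ccnc(Cl)n2)cc1[N+](=O)[O-]` gives 4730 nM in this assay; compound 3 `COc1ccc(N(C)c2ccnc(Cl)n2)cc1OCCBr` gives 3310 nM. Both replacements of the hydrogen on that aromatic carbon raised the number: a 5.2-fold higher number from compound 1 to compound 2 (0.71 log units; beyond the scatter) and a 3.6-fold higher number from compound 1 to compound 3 (0.56 log units; beyond the scatter). Compound 4 `COc1ccc(N(C)c2ccnc(Cl)n2)cc1OCCCC[Se]C#N` carries a group of 8 heavy atoms (5 carbon, 1 nitrogen, 1 oxygen, 1 selenium; no ring) in place of a hydrogen atom, on an aromatic carbon. The two measured steps bear on it directly, and both went the same way and were modest in size, so a rise beyond the scatter is expected for compound 4 as well, a 3.8-fold higher number from compound 1 to compound 4 (0.58 log units; beyond the scatter), with nothing in the series to favour one of the two measured sizes over the other. Compound 4 is therefore expected at 3500 nM, range 1300 nM to 9000 nM.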

Compound 4, half-maximal inhibitory concentration: > 10000 nM
Compound 4 ended at the assay's limit (the forecaster's own chance of this, stated with the estimate: 5%); middle value at least 2.8-fold (0.45 log units) away from the limit.
By their numbers in this assay, from the lowest: compound 1; then compounds 3 and 2 (each within the scatter of the next). At a limit, above all of these: compound 4.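

On the aromatic carbon ortho to a methoxy group, the selenium-bearing chain gives the first large step, an at least 10-fold higher number from compound 1 to compound 4 (1.03 log units; beyond the scatter), and so exceeds both earlier replacements of hydrogen. It also separates from those two substituents, an at least 3.0-fold higher number from compound 3 to compound 4 (0.48 log units; beyond the scatter) and an at least 2.1-fold higher number from compound 2 to compound 4 (0.32 log units; beyond the scatter), although compounds 2 and 3 remain within the scatter of each other. Compound 4 stands at a limit, not a number: the limit of > 10000 nM in this assay, at which 1 of the 4 values shown sits.

As far as these compounds go, the true size of these steps stays open. So does whether the rise follows chain length or the selenium and nitrile end, which a longer chain ending in bromine or an amine would help to separate.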